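Three alkyl analogues sit at the limit; a hydroxypropyl chain follows

The source may report more compounds than this note shows. Statements on the series, on what has been measured and on what is new or still open speak of the compounds shown alone.

Compound 1, `CCn1cnc2ncnc(N)c21`, in a functional assay on CHO cells for antagonist activity at adenosine receptor A2b (Homo sapiens) (on this read-out higher numbers stand for weaker inhibition and lower numbers for stronger inhibition), gives > 30000 nM, a limit of the assay.
Compound 2, `CC(C)n1cnc2ncnc(N)c21`, in this assay gives > 30000 nM, likewise a limit.
Compound 3, `CC(C)Cn1cnc2ncnc(N)c21`, in this assay gives > 30000 nM, again a limit.

Compound 1 therefore stands at the limit of this assay, with no number of its own; the two further values shown are limits as well. The steps among the measured compounds, a step that the two limits leave unreadable from compound 1 to compound 2, a step that the two limits leave unreadable from compound 1 to compound 3 and a step that the two limits leave unreadable from compound 2 to compound 3, cannot be read in size, because of the limit of > 30000 nM in this assay, at which 3 of the 3 values shown sit.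

Compound 4, `Nc1ncnc2ncn(CCCO)c12`, differs from compound 1 by hydroxymethyl in place of hydrogen on a saturated chain carbon, two bonds along the chain from an aromatic nitrogen. The measured steps that bear on it, those from compound 1 to compound 2 and from compound 1 to compound 3, are all unreadable, so no size can be carried over; the three measured values show only that changes of the chain on the aromatic nitrogen have not brought any of these compounds below the limit. Compound 4 is expected to give 30000 nM, within 10000 nM to 100000 nM. The step from compound 1 to compound 4 is thus expected to be a number no higher from compound 1 to compound 4 (the limit leaves the size open), not a change beyond the scatter.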

Compound 4, inhibition constant: > 30000 nM
Compound 4: only a limit was reported (the forecaster's own chance of this, stated with the estimate: 80%); the middle value sits exactly at the limit.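

Among these compounds, no step from compound 1, compound 2 or compound 3 to compound 4 can be read in size, because all of them stand at one value: the limit of > 30000 nM in this assay, at which 4 of the 4 values shown sit. The compounds shown leave open how far past that limit each lies in this assay, and what change to the shared core would bring a measurable number.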